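The source may hold more compounds than are shown below. What is called first, only, known or untested is meant among the compounds shown, and "the series" means these compounds.

Of the compounds shown here, three have been measured in a functional assay on the whole organism (strain Sprague-Dawley) for inhibition, with Rattus norvegicus as the target; a higher number here means that more compound is needed for the effect, a lower number that less compound is needed: compound 1 `FC(F)(F)c1cccc2cc(-c3nn[nH]n3)cnc12` gives 25 mg/kg, and compound 3 `O=C(O)c1cnc2c(C(F)(F)F)cccc2c1` gives 75 mg/kg. Compound 2 `COc1ccc(OC)c2ncc(-c3nn[nH]n3)cc12` gives only a limit of the assay, > 50 mg/kg.

From compound 1 to compound 3 the change is carboxy in place of 2H-tetrazol-5-yl on an aromatic carbon, and it brought a 3.0-fold higher number from compound 1 to compound 3 (0.48 log units; beyond the scatter). The difference between the cores of compound 1 and compound 2 is not broken down here. Compound 4 `COc1ccc(OC)c2ncc(C(=O)O)cc12` is yet to be measured; it differs from compound 2 by carboxy in place of 2H-tetrazol-5-yl on an aromatic carbon, the same change as from compound 1 to compound 3. For compound 2 the assay gives only (the limit of > 50 mg/kg in this assay, at which 1 of the 3 values shown sits). Compound 4 is therefore expected to show a step that the limit leaves unreadable from compound 2 to compound 4, resting on the step of a 3.0-fold higher number from compound 1 to compound 3 (0.48 log units; beyond the scatter), and most likely to end at a limit again. Compound 4 is estimated at 150 mg/kg, between 50 mg/kg and 500 mg/kg.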

Compound 4, minimum effective dose: > 50 mg/kg
Compound 4 gave a limit, no number; the forecaster's own chance of this, stated with the estimate: 80%; the middle value does not contradict the limit.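

No step can be read from compound 2 to compound 4, because both stand at a limit and give no number: the limit of > 50 mg/kg in this assay, at which 2 of the 4 values shown sit.

The compounds shown leave open whether carboxy in place of 2H-tetrazol-5-yl changes the dose needed on the core of compound 2 as it does on the core of compound 1.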